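This account rests on a few compounds, and the source may have more. Where it says the series, first, only, none or still open, it means among the compounds named here.

Compound 1 `ClCc1ccccc1Cn1cnc2c(Cl)nc(Cl)nc21` 1380 nM
Compound 2 `ClCc1cccc(Cn2cnc3c(Cl)ncnc32)c1` 1660 nM
Compound 3 `ClCc1ccc(Cn2cnc3nc(Cl)nc(Cl)c32)cc1` 1440 nM

These three compounds were tested in a functional assay on M14 cells (Homo sapiens) for cytotoxicity, read by sulforhodamine B assay, with a stated time of 48 h; a lower number here means a stronger inhibitor of growth, a higher number a weaker inhibitor of growth. Compound 3 gives 1440 nM, the second highest of the three numbers; compound 1 with 1380 nM and compound 2 with 1660 nM both lie within the scatter of it, so the three cannot be told apart. Compound 4 `ClCc1ccc(Cn2cnc3ncnc(Cl)c32)cc1` has not yet been measured in this assay. It differs from compound 3 in one place: hydrogen in place of chloro on an aromatic carbon. Within the data shown here, no pair of measured compounds differs by exactly this change, so its size cannot be read off directly. Compound 2, with less chlorine on the shared core than compound 3, still gives a similar number, which points to no step beyond the scatter. Compound 4 is expected to give 1500 nM, with a range from 700 nM to 3500 nM. This corresponds to an expected step of a 1.0-fold higher number from compound 3 to compound 4 (0.02 log units; within the scatter).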

Compound 4, concentration for 50% growth inhibition: 2750 nM
Compound 4: middle estimate off by 1.8-fold (0.26 log units), on the low side; the measured number falls inside the stated range.
By their numbers in this assay, from the lowest: compounds 1, 3, 2 and 4 (each within the scatter of the next).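

Among these compounds, the step of a 1.9-fold higher number from compound 3 to compound 4 (0.28 log units; within the scatter) in this assay is the first direct reading of this change. It shows that, on this aromatic carbon between two ring nitrogen atoms, hydrogen in place of chloro gives no step beyond the scatter, though this rests on a single pair of compounds. Nothing measured here offers an explanation for this result. Still open, as far as these compounds go, is whether a different group on this carbon, such as an amine or a methoxy group, would give a step beyond the scatter.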